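One more methoxy on compound 2

This account rests on a few compounds, and the source may have more. Where it says the series, first, only, none or still open, it means among the compounds named here.

- compound 1 `C=C(Br)C(=O)Nc1ccc(C(=O)/C=C/c2cc(OC)cc(OC)c2)cc1` gives 2000 nM
- compound 2 `COc1cccc(/C=C/C(=O)c2ccc(N)cc2)c1` gives 45000 nM
- compound 3 `COc1cccc(/C=C/C(=O)c2ccc(N)cc2)c1OC` gives 29000 nM

In a functional assay on FM3A cells (Mus musculus) for antiproliferative activity, with a stated time of 48 h (on this read-out lower numbers stand for stronger inhibition and higher numbers for weaker inhibition), compound 2 stands level with compound 3 within the scatter, and both give far higher numbers than compound 1 does. The next compound to be tested is compound 4 `COc1cc(/C=C/C(=O)c2ccc(N)cc2)cc(OC)c1` and it departs from compound 2 at one place. The change is methoxy in place of hydrogen on an aromatic carbon and amounts to methoxy in place of hydrogen on an aromatic carbon. Within the data shown here, the same kind of swap, made on another aromatic carbon, gave a 1.6-fold lower number from compound 2 to compound 3 (0.19 log units; within the scatter) and is the only measured step that bears on this one. Compound 1 differs from compound 2 in more than one place, so it offers no clean comparison. One earlier step is thin evidence, but it points to no change beyond the scatter in this assay and at most a slightly lower number. The expected step is a 1.5-fold lower number from compound 2 to compound 4 (0.18 log units; within the scatter) for this change. For compound 4 the estimated value is 30000 nM with an expected range (13000 nM to 70000 nM).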

Compound 4, half-maximal inhibitory concentration: 12000 nM
For compound 4 the middle estimate is 2.5-fold (0.40 log units) above the measured one; measured number outside the range, below it.
By their numbers in this assay, from the lowest: compound 1; then compound 4; then compounds 3 and 2 (each within the scatter of the next).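

In this assay, methoxy in place of hydrogen on this aromatic carbon, meta to a large group and meta to a methoxy group, gives a step beyond the scatter (a 3.8-fold lower number from compound 2 to compound 4 (0.57 log units; beyond the scatter)), whereas the same swap on another aromatic carbon stays within it (a 1.6-fold lower number from compound 2 to compound 3 (0.19 log units; within the scatter)), so in these two pairs the outcome depends on where the methoxy sits. With both methoxy groups kept, hydrogen in place of (1-bromoethenyl)carbonyl on the nitrogen also moves the number beyond the scatter (a 6.0-fold higher number from compound 1 to compound 4 (0.78 log units; beyond the scatter)). Nothing shown here accounts for the difference between the two positions.

Going by these compounds, whether ethoxy, hydroxy or a fluorine atom on this carbon would act as methoxy does remains open. So does whether a plain acetyl group on the nitrogen would match (1-bromoethenyl)carbonyl.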